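A few compounds are considered here, and "the series" means these few. Any claim that something is new, unique, unknown or untested is made for them only; others in the source may bear on it.

Measured compounds:
compound 1, `CCN(CC)S(=O)(=O)c1ccc(S(=O)(=O)N2CCC[C@@H](C(=O)N3CCOCC3)C2)cc1`, 160 nM
compound 2, `CCN(CC)S(=O)(=O)c1ccc(S(=O)(=O)N2CCC[C@@H](C(=O)N3CCC(C(F)(F)F)CC3)C2)cc1`, 110 nM

Both compounds were tested in a functional assay on MIA PaCa-2 cells (Homo sapiens) for inhibition, read by MTT assay, with a stated time of 3 days; on this read-out lower numbers stand for stronger inhibition and higher numbers for weaker inhibition. Compound 1 gives 160 nM and compound 2 gives 110 nM; the two numbers lie within the usual scatter of each other, so neither compound can be called the more potent one on this evidence. Among the measured compounds shown here, the one measured step, a 1.5-fold lower number from compound 1 to compound 2 (0.16 log units; within the scatter), swaps the ring attached to the carbonyl and leaves the number essentially unchanged.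

Compound 3, `CCN(CC)S(=O)(=O)c1ccc(S(=O)(=O)N2CCC[C@@H](C(=O)N3CCC(COC)CC3)C2)cc1`, has not yet been measured in this assay. It differs from compound 2 in one place: methoxymethyl in place of trifluoromethyl on a saturated ring carbon. This is again a change on the ring attached to the carbonyl, the same region touched by the step from compound 1 to compound 2, which stayed within the scatter. For the measured compounds named here, no other measured step bears on it. Because a 1.5-fold lower number from compound 1 to compound 2 (0.16 log units; within the scatter) was flat, a step of similar size, in no particular direction, is expected here: a 1.2-fold higher number from compound 2 to compound 3 (0.07 log units; within the scatter). The estimate for compound 3 is therefore 130 nM, expected to fall between 55 nM and 320 nM.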

Compound 3, half-maximal inhibitory concentration: 50 nM
Compound 3: middle estimate off by 2.6-fold (0.41 log units), on the high side; measured number below the stated range.
By their numbers in this assay, from the lowest: compound 3; then compounds 2 and 1 (each within the scatter of the next).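

In this assay, the ring attached to the carbonyl turns out not to be a place where every change leaves the number flat: putting methoxymethyl in place of trifluoromethyl on a saturated ring carbon, three ring bonds from the ring nitrogen, gives a 2.2-fold lower number from compound 2 to compound 3 (0.34 log units; beyond the scatter), a modest step but the first one here to clear the scatter. Exchanging morpholin-4-yl for 4-(methoxymethyl)piperidin-1-yl on the carbonyl carbon also clears it, with a 3.2-fold lower number from compound 1 to compound 3 (0.51 log units; beyond the scatter), so a modest gain shows up against both earlier ring groups. No measurement is available that would explain this drop in the number.

As far as these compounds go, whether the oxygen of methoxymethyl is needed remains open, and a plain ethyl group or a longer ether chain such as 2-methoxyethyl on the same ring carbon would help to settle that. From the compounds shown here alone, it is also open how this position responds to an aminomethyl group or a carboxylic acid, and whether the same order of compounds holds in other cell lines.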